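Swapping the hydroxyphenyl amide for a dimethylaminophenyl amide

A few compounds are considered here, and "the series" means these few. Any claim that something is new, unique, unknown or untested is made for them only; others in the source may bear on it.

Among the measured compounds shown here, compound 2 `CC(/C=N/Nc1ccc([N+](=O)[O-])cc1)=N\NC(=O)c1ccccc1O` is the only compound in this set with a number: in a functional assay on cells (Splenocyte, Mus musculus, strain BALB/c) for inhibition, read by scintillation counting and thymidine incorporation, with a stated time of 72 h (on this read-out higher numbers stand for weaker inhibition and lower numbers for stronger inhibition), compound 2 gives 1640 nM. Compound 1 `CC(/C=N/Nc1ccc([N+](=O)[O-])cc1)=N\NC(=O)c1ccccc1Nc1ccccc1` has no reported result: in this assay compound 1 stands as "not determined" (no result reported). Compound 3 `CC(/C=N/Nc1ccc([N+](=O)[O-])cc1)=N\NC(=O)c1ccc(N(C)C)cc1` differs from compound 2 in one place: 4-(dimethylamino)phenyl in place of 2-hydroxyphenyl on a carbonyl carbon. For the measured compounds named here, with no comparable step among measured compounds, the change is expected to stay close to the scatter, leaning at most slightly toward weaker inhibition, giving an estimated step of a 1.5-fold higher number from compound 2 to compound 3 (0.18 log units; within the scatter). Compound 3 is therefore estimated at 2500 nM, within a range of 600 nM to 10000 nM.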

Compound 3, half-maximal inhibitory concentration: > 12000 nM
Compound 3 ended at the assay's limit; the forecaster's own chance of this, stated with the estimate: 20%; middle value at least 4.8-fold (0.68 log units) away from the limit.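

The position on the carbonyl carbon is not indifferent to what it carries: in this assay, 4-(dimethylamino)phenyl in place of 2-hydroxyphenyl gives an at least 7.3-fold higher number from compound 2 to compound 3 (0.86 log units; beyond the scatter). Among the compounds shown here, this is the first step that can be read in the set, and it runs toward weaker inhibition. Compound 3 stands at a limit and not at a number: the limit of > 12000 nM in this assay, at which 1 of the 3 values shown sits.

The compounds shown leave open how an unsubstituted phenyl, or a phenyl carrying a methoxy group or a carboxylic acid, would read on this carbonyl carbon. They therefore do not separate the loss of the hydroxyl from the arrival of the dimethylamino group.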